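The source may hold more compounds than are shown below. What is called first, only, known or untested is meant among the compounds shown, and "the series" means these compounds.

Within the data shown here, in a functional assay on DU-145 cells (Homo sapiens) for inhibition, read by trypan blue exclusion, with a stated time of 96 h (on this read-out higher numbers stand for weaker inhibition of growth and lower numbers for stronger inhibition of growth), two compounds built on a shared core have numbers so far. Compound 1 `COc1ccc(/C=C(/SCc2ccc(F)cc2)C(=O)c2ccc(Br)cc2)cc1` gives 50000 nM, while compound 2 `O=C(/C(=C\c1ccc(O)cc1)SCc1ccc(F)cc1)c1ccc(Br)cc1` gives 10000 nM, the lower number of the two and so the stronger inhibition of growth.

The next compound, compound 3 `Cc1ccsc1/C=C(/SCc1ccc(F)cc1)C(=O)c1ccc(Br)cc1`, differs from compound 2 in one place: 3-methylthiophen-2-yl in place of 4-hydroxyphenyl on a double-bonded chain carbon bound to a double-bonded chain carbon. Put simply, 3-methylthiophen-2-yl comes in place of 4-hydroxyphenyl on a double-bonded chain carbon bound to a double-bonded chain carbon.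

Among the measured compounds shown here, only one measured step bears on this change: a 5.0-fold lower number from compound 1 to compound 2 (0.70 log units; beyond the scatter). It is a modest step, made by putting hydrogen in place of methyl on an oxygen on an aromatic ring, and it shows that a small edit to this part of the molecule can move the number. Compound 3 has no hydroxy group, and compound 1, which also lacks one, stands higher at 50000 nM. For the measured compounds named here, no measured compound carries a thiophene ring, so this guide is rough.

The expected change is a 2.5-fold higher number from compound 2 to compound 3 (0.40 log units; beyond the scatter), a modest rise. For compound 3 the estimated value is 25000 nM, with an expected range from 7000 nM to 70000 nM.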

Compound 3, concentration for 50% growth inhibition: 50000 nM
Compound 3: the middle estimate sits 2.0-fold (0.30 log units) below what was measured, within the range that was stated.
By their numbers in this assay, from the lowest: compound 2; then compounds 1 and 3 (each within the scatter of the next).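

In this assay, putting 3-methylthiophen-2-yl in place of 4-hydroxyphenyl gives a 5.0-fold higher number from compound 2 to compound 3 (0.70 log units; beyond the scatter) and so gives up the lower number that compound 2 had reached. Putting the same thiophene group in place of 4-methoxyphenyl gives no change at the digits printed from compound 1 to compound 3 (within the scatter) and shows that, on this read-out, a five-membered aromatic ring with one sulfur atom cannot be told apart from the methoxy-bearing six-membered ring at this place. Among these three compounds, only compound 2, with its 4-hydroxyphenyl group, stands apart from the other two, and nothing measured here accounts for that difference.

The compounds shown leave open whether the lower number of compound 2 depends on the hydroxy group alone or also on the six-membered ring that carries it, since a thiophene ring bearing a hydroxy group would be needed to separate the two. They also leave open how an amine or a carboxylic acid in place of that hydroxy group would compare in this assay.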